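Restoring the nitro group on the aminophenyl ring

The source may hold more compounds than are shown below. What is called first, only, known or untested is meant among the compounds shown, and "the series" means these compounds.

Measured so far:
compound 1 `O=c1c(-c2cccc([N+](=O)[O-])c2)nc2ccccc2n1Cc1ccccc1` in an assay on cells for activation of Cystic fibrosis transmembrane conductance regulator (Homo sapiens), read by fluorescence, with a stated time of 10 min; on this read-out lower numbers stand for an effect already at smaller amounts and higher numbers for an effect only at larger amounts of compound: 9 nM
compound 2 `Nc1ccc(C(=O)O)cc1-c1nc2ccccc2n(Cc2ccccc2)c1=O`: > 10000 nM

Compound 2 reports only a limit in this assay, > 10000 nM; it sits at the limit of > 10000 nM in this assay, at which 1 of the 2 values shown sits. Compound 3 `Nc1ccc([N+](=O)[O-])cc1-c1nc2ccccc2n(Cc2ccccc2)c1=O` differs from compound 2 by nitro in place of carboxy on an aromatic carbon. Compound 1 carries that same nitro group and gives 9 nM in this assay. The expected step is an at least 200-fold lower number from compound 2 to compound 3 (2.30 log units; beyond the scatter), well beyond the scatter and toward smaller amounts. Compound 3 is estimated at 50 nM, with a range of 8 nM to 600 nM.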

Compound 3, half-maximal effective concentration: 200 nM
Compound 3: middle estimate off by 4.0-fold (0.60 log units), on the low side; the range from low to high includes it.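

In this assay, nitro in place of carboxy on the aromatic carbon para to an amino group gives an at least 50-fold lower number from compound 2 to compound 3 (1.69 log units; beyond the scatter), so this position tolerates nitro far better than carboxy. Compound 2 reports only a limit, so the true size of that step cannot be read: the limit of > 10000 nM in this assay, at which 1 of the 3 values shown sits.

With nitro in place, amino in place of hydrogen is not free, giving a 22-fold higher number from compound 1 to compound 3 (1.35 log units; beyond the scatter). The compounds shown leave open how a nitrile or an amide would read in place of nitro on this carbon, and how a methyl or a hydroxyl would read in place of the amino group.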